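Methoxybenzyl step on a shared azaindazole-type amidine series

A few compounds are considered here, and "the series" means these few. Any claim that something is new, unique, unknown or untested is made for them only; others in the source may bear on it.

Compound 1 `CN1CCN(c2ccc(NC(=N)c3cc4cnn(C)c4cn3)cc2)CC1` carries a methylated saturated nitrogen on its core and gives 32300 nM in a functional assay on PC-3 cells (Homo sapiens) for cytotoxicity, read by MTT assay, with a stated time of 72 h; a lower number here means a stronger inhibitor, a higher number a weaker inhibitor. Compound 2 `COc1ccc(Cn2ncc3cc(C(=N)Nc4ccc(N5CCN(C)CC5)cc4)ncc32)cc1` differs from compound 1 by 4-methoxyphenyl in place of hydrogen on a saturated chain carbon bound to an aromatic nitrogen; in this assay compound 2 gives 6100 nM, so the step of a 5.3-fold lower number from compound 1 to compound 2 (0.72 log units; beyond the scatter) is modest but beyond the scatter. Compound 3 `Cn1cc2cc(C(=N)Nc3ccccc3)ncc2n1` shares the amidine but its core differs from that of compound 1 in a way that is not broken down here, and for compound 3 this assay reports "not determined" (no result reported). Compound 4 `COc1ccc(Cn2cc3cc(C(=N)Nc4ccccc4)ncc3n2)cc1` differs from compound 3 by 4-methoxyphenyl in place of hydrogen on a saturated chain carbon bound to an aromatic nitrogen, the same change as seen between compound 1 and compound 2, at the same place. Among the measured compounds shown here, because a 5.3-fold lower number from compound 1 to compound 2 (0.72 log units; beyond the scatter) is the only measured instance and compound 3 has no value, the expected step for compound 4 rests on a single pair and on compound 1 alone. Compound 4 is estimated at 10000 nM in this assay, expected between 2000 nM and 50000 nM.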

Compound 4, half-maximal inhibitory concentration: 2040 nM
Compound 4: the middle estimate sits 4.9-fold (0.69 log units) above what was measured, and the stated range covers the measured number.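

Among the compounds shown here, no step from compound 3 to compound 4 can be read in this assay: compound 3 has no single number, and compound 4 at 2040 nM stands alone. From the compounds shown here alone, whether the 4-methoxyphenyl change on the core of compound 3 matches a 5.3-fold lower number from compound 1 to compound 2 (0.72 log units; beyond the scatter) stays open. No supporting data bear on this result.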